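Chloro position on the phenylpiperazine arm of compound 2

A few compounds are considered here, and "the series" means these few. Any claim that something is new, unique, unknown or untested is made for them only; others in the source may bear on it.

Measured so far:
compound 1 `S=c1oc(-c2ccc3c(c2)OCCO3)nn1CN1CCN(c2ccc(Cl)cc2)CC1`: > 50000 nM
compound 2 `S=c1oc(-c2ccc3c(c2)OCCO3)nn1CN1CCN(c2ccccc2)CC1`: > 50000 nM

In a functional assay on HeLa cells (Homo sapiens) for antiproliferative activity, read by MTT assay, with a stated time of 48 h (a lower number here means a stronger inhibitor, a higher number a weaker inhibitor), compound 1 gives > 50000 nM, which is a limit of the assay and not a number. In this assay compound 2 gives > 50000 nM, again a limit only. Where compound 2 stands is therefore known only as a limit. For the measured compounds named here, the one measured step, a step that the two limits leave unreadable from compound 1 to compound 2, cannot be read for size, because the limit of > 50000 nM in this assay, at which 2 of the 2 values shown sit, holds both ends of it.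

Compound 3 `S=c1oc(-c2ccc3c(c2)OCCO3)nn1CN1CCN(c2ccccc2Cl)CC1` differs from compound 2 in one place: chloro in place of hydrogen on an aromatic carbon. Going by the values given here, the only step that bears on a chloro on this ring is the unreadable one from compound 1 to compound 2, so no direction or size beyond the scatter can be taken from it. The expectation for this assay is that compound 3 stays where compound 2 stands, at the limit.

Compound 3 is expected to give 60000 nM, with an estimated range of 20000 nM to 200000 nM. The expected step that the limit leaves unreadable from compound 2 to compound 3 is an estimate carrying no readable precedent.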

Compound 3, half-maximal inhibitory concentration: 37400 nM
Beside the measured number, compound 3's estimate is 1.6-fold (0.21 log units) above it, and the stated range covers the measured number.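

Among the three compounds, only compound 3 gives a number and not a limit in this assay, at 37400 nM, so the 2-chlorophenyl arm is the one case here with a readable value, and a chloro ortho to a large group gives the series its first anchor for comparison. Against the unsubstituted phenyl arm the result is an at least 1.3-fold lower number from compound 2 to compound 3 (0.12 log units; that floor lies within the scatter), and against the 4-chlorophenyl arm it is an at least 1.3-fold lower number from compound 1 to compound 3 (0.12 log units; that floor lies within the scatter), so neither comparison shows a difference beyond the scatter, though both are now bounded on one side where the earlier step had no readable size at all. The true size of both steps stays unknown because one end of each is a limit: the limit of > 50000 nM in this assay, at which 2 of the 3 values shown sit.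

Going by these compounds, whether the chloro itself matters at this place stays open, as does what a fluoro, a bromo or a methoxy would give in its stead on the same ring. Also open, on these data alone, is whether any group on this arm, such as an amine or a carboxylic acid, would bring the series well clear of the limit.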